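Swapping a Para Chloro for Hydroxymethyl in Urea Inhibitors

The source may hold more compounds than are shown below. What is called first, only, known or untested is meant among the compounds shown, and "the series" means these compounds.

Three ureas sharing one core have been measured in an assay on microsomes for inhibition of acyl-CoA:cholesterol acyltransferase (Oryctolagus cuniculus); on this read-out lower numbers stand for stronger inhibition and higher numbers for weaker inhibition. Compound 1 `CC(C)c1cccc(C(C)C)c1NC(=O)NCC1(c2ccc(F)cc2)CCCC1` gives 23 nM. Compound 2 `CC(C)c1cccc(C(C)C)c1NC(=O)NCC1(c2ccc(Cl)cc2)CCCC1` gives 32 nM, the highest of the three numbers, though its nearest neighbour is compound 1 and the gap a 1.4-fold higher number from compound 1 to compound 2 (0.14 log units; within the scatter) is small. Compound 3 `COc1cccc(C2(CNC(=O)Nc3c(C(C)C)cccc3C(C)C)CCCC2)c1` gives 13 nM, the lowest number; the step of a 2.5-fold lower number from compound 2 to compound 3 (0.39 log units; beyond the scatter) is modest, while a 1.8-fold lower number from compound 1 to compound 3 (0.25 log units; within the scatter) stays within the scatter.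

The next compound, compound 4 `CC(C)c1cccc(C(C)C)c1NC(=O)NCC1(c2ccc(CO)cc2)CCCC1`, differs from compound 2 by hydroxymethyl in place of chloro on an aromatic carbon. Among the compounds with values here, no measured step exchanges chloro for a hydroxymethyl group, so the expectation rests on what the ring substituent has done so far. The chloro-to-fluoro comparison a 1.4-fold higher number from compound 1 to compound 2 (0.14 log units; within the scatter) barely moved the number, and the larger move a 2.5-fold lower number from compound 2 to compound 3 (0.39 log units; beyond the scatter) came only with a different ring pattern. Hydroxymethyl is a new kind of group here, and the measured steps give no clear direction for it; a change of roughly the size of those already seen, in either direction, seems the most reasonable expectation.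

Compound 4 is therefore estimated at 28 nM in this assay, within 10 nM to 80 nM, meaning an expected step of a 1.1-fold lower number from compound 2 to compound 4 (0.06 log units; within the scatter).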

Compound 4, half-maximal inhibitory concentration: 26 nM
The estimate for compound 4 lay 1.1-fold (0.03 log units) above the measured number; the range from low to high includes it.
By their numbers in this assay, from the lowest: compounds 3, 1, 4 and 2 (each within the scatter of the next, the first and the last beyond it).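

In this assay, the hydroxymethyl group brings one hydrogen-bond donor and one hydrogen-bond acceptor to a place on the aromatic ring, para to a large group, where chloro carries neither, yet a 1.2-fold lower number from compound 2 to compound 4 (0.09 log units; within the scatter). The comparison with the fluoro compound reads the same way, with a 1.1-fold higher number from compound 1 to compound 4 (0.05 log units; within the scatter), so this position accepts a group of a new kind, with two heavy atoms instead of one, without a step beyond the scatter. Even a 2.0-fold higher number from compound 3 to compound 4 (0.30 log units; within the scatter) stays within the scatter, which places compound 4 within reach of both compound 2 and compound 3, although those two lie beyond the scatter of each other, and no other data here bear on why these numbers sit so close.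

As far as these compounds go, it remains open whether the position accepts almost any group or only those seen so far, which an amine, a carboxylic acid or a longer chain ending in a hydroxyl group at the same place could help to settle. From the compounds shown here alone, it is also open whether hydroxymethyl would behave the same way on the 3-substituted ring pattern of compound 3.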